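A few compounds are considered here, and "the series" means these few. Any claim that something is new, unique, unknown or untested is made for them only; others in the source may bear on it.

Three compounds of one series were tested in an ADME assay on HepG2 cells (Homo sapiens) for cytotoxicity, read by MTT assay, with a stated time of 48 h; a higher number here means a weaker inhibitor, a lower number a stronger inhibitor. Compound 1 `N#Cc1ccc(-c2ccc(CNCCNc3ccnc4cc(Cl)ccc34)s2)cc1` gives 26100 nM in this assay. Compound 3 `Clc1ccc2c(NCCNCc3ccc(-c4cccnc4)s3)ccnc2c1` differs from compound 1 in one place, (pyridin-3-yl in place of 4-cyanophenyl on an aromatic carbon), and in this assay compound 3 gives 16400 nM, a step of a 1.6-fold lower number from compound 1 to compound 3 (0.20 log units; within the scatter). Compound 2 `N#Cc1ccc(-c2ccc(CNCCCNc3ccnc4cc(Cl)ccc34)s2)cc1` carries a different core from compound 1; the difference between the two cores is not broken down here. In this assay compound 2 gives 3550 nM, the lowest number of the three, and both compound 1 and compound 3 sit well above it.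

Compound 4 `Clc1ccc2c(NCCCNCc3ccc(-c4cccnc4)s3)ccnc2c1` has not yet been measured. For the measured compounds named here, it stands to compound 2 as compound 3 stands to compound 1: the change is pyridin-3-yl in place of 4-cyanophenyl on an aromatic carbon, the same change at the same place as the one between compound 1 and compound 3. That earlier change moved the number only a little, so the account rests on the expectation that compound 4 will keep close to compound 2. The step from compound 2 to compound 4 is expected to be about a 1.3-fold lower number from compound 2 to compound 4 (0.10 log units; within the scatter), because the same change gave a 1.6-fold lower number from compound 1 to compound 3 (0.20 log units; within the scatter). Compound 4 is therefore estimated at 2800 nM in this assay, with a range from 1200 nM to 6500 nM. Whether the shared core of compound 2 and compound 4 behaves like that of compound 1 and compound 3 under this change remains to be seen from the measurement.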

Compound 4, half-maximal inhibitory concentration: 21600 nM
Estimate against measurement, compound 4: 7.7-fold (0.89 log units) below, and the stated range ends below it.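

In this assay, pyridin-3-yl in place of 4-cyanophenyl on the core shared by compound 2 and compound 4 gives a 6.1-fold higher number from compound 2 to compound 4 (0.78 log units; beyond the scatter), so the near-neutral result of this change on the other core is not repeated here. The change therefore does not carry from one core to the other in this series, and its effect has to be read separately on each of the two cores: the same change on two cores in this assay, a 1.6-fold lower number (0.20 log units; within the scatter) from compound 1 to compound 3 and a 6.1-fold higher number (0.78 log units; beyond the scatter) from compound 2 to compound 4, 9.7-fold (0.99 log units) apart, beyond the scatter of two such steps This rests on a single pair of steps, so it shows that the two cores respond differently, but not which feature of the cores accounts for the difference or how the change would behave on any further core.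

The compounds shown leave open whether other groups at this place on the ring with the sulfur, such as an unsubstituted phenyl or a pyridin-4-yl, would separate the two cores in the same way. They also leave open whether a core with a longer chain would follow compound 2 and compound 4 or compound 1 and compound 3 under this change.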